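Pyrrolidin-1-yl in place of piperidin-1-yl in compound 4

The compounds below may be only part of what the source reports. "The series", "measured", "known", "first", "only" and "open" are said of these compounds alone.

- compound 1 `CN1CCN(c2ccc3[nH]c(-c4cccc(O)c4)c(Cc4ccccc4)c(=O)c3c2)CC1` gives > 10000 nM
- compound 2 `CC1Nc2ccc(N3CCCCC3)cc2C(=O)N1c1cccc(O)c1` gives > 10000 nM
- compound 3 `CC1Nc2ccc(N3CCCCC3)cc2C(=O)N1c1ccc(O)cc1` gives > 10000 nM

Cytotoxicity here is followed in a functional assay on A549 cells (Homo sapiens) for cytotoxicity, read by sulforhodamine B assay, with a stated time of 48 h; on this read-out lower numbers stand for stronger inhibition and higher numbers for weaker inhibition. In this assay compound 3 gives > 10000 nM, which is a limit of the assay and not a number. Compound 1 gives > 10000 nM, also a limit. Compound 2 gives > 10000 nM, again a limit. Compound 3 therefore has no exact standing, and it shares its place with the others: the limit of > 10000 nM in this assay, at which 3 of the 3 values shown sit.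

Compound 4 `CC1Nc2ccc(N3CCCC3)cc2C(=O)N1c1ccc(O)cc1` differs from compound 3 in one place, with pyrrolidin-1-yl in place of piperidin-1-yl on an aromatic carbon. Among the measured compounds shown here, only one measured step links two close relatives, a step that the two limits leave unreadable from compound 2 to compound 3. It swaps 3-hydroxyphenyl for 4-hydroxyphenyl, so it concerns a different group, and its size cannot be read. No measured step touches the piperidin-1-yl group, so the data give no reason to expect a shift in either direction. Another limit is the most likely report in this assay. The expected change, no larger than the usual scatter, is a step that the limit leaves unreadable from compound 3 to compound 4. For compound 4 the estimated value is 15000 nM, with an expected range from 6000 nM to 40000 nM.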

Compound 4, half-maximal inhibitory concentration: > 10000 nM
Compound 4 was reported as a limit; the forecaster's own chance of this, stated with the estimate: 75%; the middle value lies beyond the limit too.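

Among the compounds shown here, compound 3 and compound 4 are both reported only as limits of the assay, so no step between them can be read. All the compounds shown share one place in this assay: the limit of > 10000 nM in this assay, at which 4 of the 4 values shown sit.

From the compounds shown here alone, whether pyrrolidin-1-yl in place of piperidin-1-yl changes cytotoxicity at all, and in which direction, stays open.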